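Piperidine for dimethylpiperidine on the urea carbonyl of compound 2

A few compounds are considered here, and "the series" means these few. Any claim that something is new, unique, unknown or untested is made for them only; others in the source may bear on it.

Compound 1 `COc1ccc(Cl)cc1NC(=O)CN1CCN(S(=O)(=O)N2CCN(C(=O)N3CCCCCC3)CC2)CC1` returns > 10000 nM in an assay on HEK293 cells for activation of potassium channel subfamily T member 1 (Homo sapiens), read by thallium flux (on this read-out higher numbers stand for an effect only at larger amounts of compound and lower numbers for an effect already at smaller amounts), which is a limit of the assay and not a number. Within the data shown here, compound 2 `COc1ccc(Cl)cc1NC(=O)CN1CCN(S(=O)(=O)N2CCN(C(=O)N3CCC(C)(C)CC3)CC2)CC1` gives 9000 nM in this assay, the only number in the set. The step of an at least 1.1-fold lower number from compound 1 to compound 2 (0.04 log units; that floor lies within the scatter) stays within the scatter. Compound 3 `COc1ccc(Cl)cc1NC(=O)CN1CCN(S(=O)(=O)N2CCN(C(=O)N3CCCCC3)CC2)CC1` carries piperidin-1-yl in place of 4,4-dimethylpiperidin-1-yl on a carbonyl carbon. The one measured step at this carbonyl bears on it, and the evidence on the measured steps is the limit of > 10000 nM in this assay, at which 1 of the 2 values shown sits; no shown step removes a pair of methyl groups from a piperidin-1-yl. The expected step of a 1.1-fold higher number from compound 2 to compound 3 (0.05 log units; within the scatter) is therefore none beyond the scatter. For compound 3 the estimate is 10000 nM, range 4000 nM to 25000 nM, with a real chance that only a limit is reported.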

Compound 3, half-maximal effective concentration: > 10000 nM
Compound 3: a limit, no number (the forecaster's own chance of this, stated with the estimate: 50%); the middle value lies on the limit itself.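

Piperidin-1-yl in place of 4,4-dimethylpiperidin-1-yl on the carbonyl carbon gives an at least 1.1-fold higher number from compound 2 to compound 3 (0.04 log units; that floor lies within the scatter) in this assay, and the step from compound 1 to compound 3 joins two limits and cannot be read. Of the three groups at this position, only 4,4-dimethylpiperidin-1-yl in compound 2 gives a number, yet no step separates it beyond the scatter, and the series stays at the end of the read-out: the limit of > 10000 nM in this assay, at which 2 of the 3 values shown sit.

On these data alone, whether morpholin-4-yl or an open-chain diethylamino group on this carbonyl carbon would give a number clear of that limit remains open.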